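Bis-benzimidazole aryl hydrazones: chloro to nitro step

The compounds below may be only part of what the source reports. "The series", "measured", "known", "first", "only" and "open" are said of these compounds alone.

Compound 1 `Cc1ccc(NN=C(c2nc3ccccc3[nH]2)c2nc3ccccc3[nH]2)cc1` and compound 2 `Clc1ccc(NN=C(c2nc3ccccc3[nH]2)c2nc3ccccc3[nH]2)cc1` share one core and differ only in the group on the aryl ring. In a functional assay on HT-29 cells (Homo sapiens) for cytotoxicity, read by MTT assay, with a stated time of 72 h (on this read-out lower numbers stand for stronger inhibition and higher numbers for weaker inhibition), compound 1 gives 95900 nM; in this assay compound 2 gives 114000 nM. Among the measured compounds shown here, compound 2 stands at the higher of the two numbers so far, with compound 1 its nearest neighbour, the two within the scatter of each other. Compound 3 `O=[N+]([O-])c1ccc(NN=C(c2nc3ccccc3[nH]2)c2nc3ccccc3[nH]2)cc1` is not yet measured. It differs from compound 2 by nitro in place of chloro on an aromatic carbon. For the measured compounds named here, the only measured step that bears on this position is a 1.2-fold higher number from compound 1 to compound 2 (0.08 log units; within the scatter), an exchange of one substituent on the same aromatic carbon that moved nothing beyond the scatter. Going by the values given here, no measured step involves the nitro group, so the expectation rests on that single exchange alone. Compound 3 is therefore expected to show a 1.1-fold lower number from compound 2 to compound 3 (0.04 log units; within the scatter). Compound 3 is estimated at 105000 nM, with a range from 40000 nM to 280000 nM.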

Compound 3, half-maximal inhibitory concentration: 17700 nM
Compound 3: the middle estimate sits 5.9-fold (0.77 log units) above what was measured; measured number outside the range, below it.
By their numbers in this assay, from the lowest: compound 3; then compounds 1 and 2 (each within the scatter of the next).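

In this assay nitro on this aromatic carbon gives a 6.4-fold lower number from compound 2 to compound 3 (0.81 log units; beyond the scatter) and a 5.4-fold lower number from compound 1 to compound 3 (0.73 log units; beyond the scatter) while methyl and chloro at the same place stay within the scatter of each other. The position therefore does respond to the group it carries, which the first pair alone did not reveal. Among the three groups shown, only the 4-nitrophenyl compound separates from the others, and nothing available here accounts for that separation.

Going by these compounds, whether this step belongs to nitro alone or would also appear with a nitrile, an amine or a carboxylic acid on the same carbon remains open. Also open, on these data alone, is whether nitro would keep the step on another carbon of the aryl ring, since all three groups shown sit para to a large group.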